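Bicyclic adenosine series: 3-iodobenzyl added to compound 1

This account rests on a few compounds, and the source may have more. Where it says the series, first, only, none or still open, it means among the compounds named here.

The series opens with compound 1 `Nc1ncnc2c1ncn2[C@@H]1O[C@@]2(CO)CN[C@@H]1[C@@H]2O`. In a functional assay for antagonist activity at adenosine receptor A3 (Homo sapiens), with a stated time of 30 min (on this read-out higher numbers stand for weaker inhibition and lower numbers for stronger inhibition), compound 1 reaches only > 100000 nM, which is a limit of the assay and not a number, so compound 1 stands at the weak end of the values shown (the limit of > 100000 nM in this assay, at which 1 of the 2 values shown sits). Compound 2 `CNC(=O)[C@@]12CN[C@@H]([C@H](n3cnc4c(N)ncnc43)O1)[C@@H]2O` gives 170 nM in this assay. Among the measured compounds shown here, the single measured step, an at least 580-fold lower number from compound 1 to compound 2 (2.76 log units; beyond the scatter), alters a substituent on a saturated ring carbon. Compound 3 `OC[C@@]12CN[C@@H]([C@H](n3cnc4c(NCc5cccc(I)c5)ncnc43)O1)[C@@H]2O` instead carries the change 3-iodobenzyl in place of hydrogen on a nitrogen on an aromatic ring and keeps the hydroxymethyl of compound 1. For the measured compounds named here, no measured step touches that nitrogen, so the step from compound 1 to compound 2 does not bear on the change directly; it shows only that the hydroxymethyl core can move from the limit to a measured number. With compound 1 at a limit, any number for compound 3 reads as a step of undefined size. Compound 3 is expected to give 20000 nM (range 2000 nM to 150000 nM) in this assay, which amounts to an estimated at least 5.0-fold lower number from compound 1 to compound 3 (0.69 log units; beyond the scatter), with a real chance that only a limit is reported again.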

Compound 3, half-maximal inhibitory concentration: 8.2 nM
Estimate against measurement, compound 3: 2400-fold (3.39 log units) above; the measured number lies below the stated range.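

In this assay, 3-iodobenzyl in place of hydrogen on a nitrogen on an aromatic ring gives an at least 12000-fold lower number from compound 1 to compound 3 (4.08 log units; beyond the scatter), so this nitrogen tolerates a large substituent and the change alone carries the hydroxymethyl core from the limit to a measured number. The methylcarbamoyl of compound 2 is therefore not required for a measured number on this core. Compound 1 stands at a limit of the assay, not a number, so the true size of the step stays unknown and the printed size is only a floor: the limit of > 100000 nM in this assay, at which 1 of the 3 values shown sits.

The compounds shown leave open how much of the step belongs to the iodine and how much to the benzyl, which a plain benzyl or a 3-chlorobenzyl on the same nitrogen would separate. Also open, from the compounds shown here alone, is whether 3-iodobenzyl and methylcarbamoyl combine on the shared core.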